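The source may hold more compounds than are shown below. What is called first, only, known or untested is meant among the compounds shown, and "the series" means these compounds.

For the measured compounds named here, in a functional assay on A549 cells (Homo sapiens) for antiproliferative activity, read by MTT assay, with a stated time of 48 h (on this read-out higher numbers stand for weaker inhibition and lower numbers for stronger inhibition), two compounds have numbers so far. Compound 1 (`O=C(/C=C/c1ccc(O)c(O)c1)N1CCN(c2cccc(Cl)c2)CC1`) gives 1.29 ug/mL on this read-out, and compound 2 (`COc1cccc(N2CCN(C(=O)/C=C/c3ccc(O)c(O)c3)CC2)c1`) gives 1.27 ug/mL on the same read-out. Going by the values given here, these two values lie within the scatter of each other, so compound 2 stands level with compound 1, the only other measured compound.

Compound 3 (`O=C(/C=C/c1ccc(O)c(O)c1)N1CCN(c2cccc(C(F)(F)F)c2)CC1`) keeps the shared core and carries trifluoromethyl in place of methoxy on an aromatic carbon. Among the compounds with values here, only one measured step bears on this change, a swap from chloro to methoxy on an aromatic carbon. With only a 1.0-fold lower number from compound 1 to compound 2 (0.01 log units; within the scatter) to go on, no step beyond the scatter is expected in this assay for the new swap. Within the data shown here, a single step is thin evidence, however, and no compound with trifluoromethyl has been measured yet.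

The estimate therefore means a 1.0-fold higher number from compound 2 to compound 3 (0.01 log units; within the scatter) as the expected step. Compound 3 is estimated at 1.3 ug/mL with an expected range of 0.6 ug/mL to 3 ug/mL for the measurement still to come.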

Compound 3, half-maximal inhibitory concentration: 1.74 ug/mL
Compound 3: the middle estimate sits 1.3-fold (0.13 log units) below what was measured; the measured number falls inside the stated range.
By their numbers in this assay, from the lowest: compounds 2, 1 and 3 (each within the scatter of the next).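

In this assay this ring position, meta to a large group, has now held three different groups, and the numbers do not separate them: the data show a 1.4-fold higher number from compound 2 to compound 3 (0.14 log units; within the scatter) and a 1.3-fold higher number from compound 1 to compound 3 (0.13 log units; within the scatter). Compared with the first pair, this adds a swap that changes more of the group's make-up, since methoxy has 2 heavy atoms and 1 hydrogen-bond acceptor while trifluoromethyl has 4 heavy atoms and 0 hydrogen-bond acceptors, yet the step stays within the scatter, so across compounds 1, 2 and 3 the choice among chloro, methoxy and trifluoromethyl makes no readable difference in this assay. No measurement here offers a reason why these three groups read alike.

From the compounds shown here alone, all three groups are uncharged, so it remains open whether a charged group such as an amine or a carboxylic acid, or a longer chain such as butoxy, would also leave the number in place at this position. The compounds shown also leave open whether the same swaps would read alike at another position on this ring.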